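This account rests on a few compounds, and the source may have more. Where it says the series, first, only, none or still open, it means among the compounds named here.

The series shares one core, seen in compound 1 `Cc1cc(NC(=O)Nc2ccccc2C(F)(F)F)c2ccccc2n1`, compound 2 `Cc1cc(NC(=O)Nc2ccc(N)cc2)c2ccccc2n1` and compound 3 `Cc1cc(NC(=O)Nc2ccccc2OC(F)(F)F)c2ccccc2n1`, and all three have been run in an ADME assay on BJ cells (Homo sapiens) for cytotoxicity, with a stated time of 72 h; a lower number here means that less compound is needed, a higher number that more compound is needed for the effect. In this assay compound 1 gives > 25000 nM, which is a limit of the assay and not a number. In the same assay compound 2 gives > 25000 nM, again a limit. Compound 3 gives > 25000 nM, also a limit. Within the data shown here, the single one-point step measured, a step that the two limits leave unreadable from compound 1 to compound 3, cannot be read because of the limit of > 25000 nM in this assay, at which 3 of the 3 values shown sit. Compound 2 therefore stands at the limit, together with the two further values shown, which are limits as well.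

Compound 4 `Cc1cc(NC(=O)Nc2ccc(C(F)(F)F)cc2)c2ccccc2n1` differs from compound 2 by trifluoromethyl in place of amino on an aromatic carbon. Among the measured compounds shown here, no measured step bears directly on this change, and the only measured step is unreadable. None of the three measured compounds moved off the limit, so no step beyond the scatter is expected in this assay for compound 4. The expected step is a step that the limit leaves unreadable from compound 2 to compound 4. Compound 4 is estimated at 40000 nM, with a range from 10000 nM to 200000 nM, and most likely it will again be reported only as a limit.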

Compound 4, half-maximal effective concentration: > 25000 nM
Compound 4: no number, only a limit (the forecaster's own chance of this, stated with the estimate: 85%); the middle value lies beyond the limit too.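

In this assay compound 4 gives > 25000 nM, a limit of the assay and not a number. The step between compound 2 and compound 4 therefore cannot be read: the limit of > 25000 nM in this assay, at which 4 of the 4 values shown sit.

The compounds shown leave open where any of them would give a readable value, and which change on the shared core would produce one.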